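Sulfur-linked arylmethyl group variation: compounds 1 to 3

The compounds below may be only part of what the source reports. "The series", "measured", "known", "first", "only" and "open" are said of these compounds alone.

Measured compounds:
compound 1, `Cc1cc(Nc2cc(-c3ccccc3)[nH]n2)n2nc(SCc3c(Cl)cccc3Cl)nc2n1`: 39600 nM in an ADME assay on GES1 cells (Homo sapiens) for inhibition, read by MTT assay, with a stated time of 72 h; on this read-out lower numbers stand for stronger inhibition and higher numbers for weaker inhibition
compound 2, `Cc1cc(Nc2cc(-c3ccccc3)[nH]n2)n2nc(SCc3csc4ccccc34)nc2n1`: 29200 nM in this assay

Among the compounds with values here, compound 2 holds the lowest of the two numbers, yet the one measured step, a 1.4-fold lower number from compound 1 to compound 2 (0.13 log units; within the scatter), lies within the scatter, so compound 1 and compound 2 are not separated in this assay.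

Compound 3, `Cc1cc(Nc2cc(-c3ccccc3)[nH]n2)n2nc(SCc3ccc(Cl)cc3)nc2n1`, is not yet measured. Its difference from compound 2: 4-chlorophenyl in place of 1-benzothiophen-3-yl on a saturated chain carbon bound to a sulfur. The step from compound 1 to compound 2 bears on this, as it also exchanged the group on a saturated chain carbon bound to a sulfur, from 2,6-dichlorophenyl to 1-benzothiophen-3-yl, and stayed within the scatter. No measurement of 4-chlorophenyl at this place exists in the series. For compound 3 the expected step is a 1.1-fold higher number from compound 2 to compound 3 (0.05 log units; within the scatter), with no direction beyond the scatter. The estimate for compound 3 in this assay is 33000 nM, range 14000 nM to 80000 nM.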

Compound 3, half-maximal inhibitory concentration: 31800 nM
Compound 3: the middle estimate sits 1.0-fold (0.02 log units) above what was measured; measured number inside the range.
By their numbers in this assay, from the lowest: compounds 2, 3 and 1 (each within the scatter of the next).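

Exchanging 1-benzothiophen-3-yl for 4-chlorophenyl on a saturated chain carbon bound to a sulfur gives a 1.1-fold higher number from compound 2 to compound 3 (0.04 log units; within the scatter) in this assay, and exchanging 2,6-dichlorophenyl for the same group gives a 1.2-fold lower number from compound 1 to compound 3 (0.10 log units; within the scatter). The three aryl groups are therefore not separated at this place: neither the loss of the five-membered aromatic ring of 1-benzothiophen-3-yl nor the difference between 2,6-dichlorophenyl and 4-chlorophenyl carries the number beyond the scatter. No measurement at hand accounts for this flat result.

Going by these compounds, all three compounds carry an aromatic group on this chain carbon, so it remains open whether an amine, a carboxylic acid or a longer alkyl chain here would separate from them. On these data alone, the effect of an oxygen in place of the linking sulfur also remains open.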